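Extending the methyl chain of compound 3 to butyl

The compounds below may be only part of what the source reports. "The series", "measured", "known", "first", "only" and "open" are said of these compounds alone.

Of the compounds shown here, three sharing one core have been measured in a functional assay on the whole organism with Rattus norvegicus as the target, at a dose of 3 mg/kg by the oral route; a lower number here means a weaker effect, a higher number a stronger effect of the compound at the dose given. Compound 1 `Cc1cc(C(=O)Nc2nn[nH]n2)nc(-c2ccccc2)c1` gives 50%. Compound 2 `COc1cccc(-c2cc(C)cc(C(=O)Nc3nn[nH]n3)n2)c1` gives 65%, and compound 3 `Cc1cccc(-c2cc(C)cc(C(=O)Nc3nn[nH]n3)n2)c1` gives 61%. Compound 3 stands second highest of the three numbers: its nearest neighbour is compound 2, a step of a number 4 percentage points lower from compound 2 to compound 3 (within the scatter) that lies within the scatter, while its furthest is compound 1, with a number 11 percentage points higher from compound 1 to compound 3 (beyond the scatter), a step beyond the scatter. The other measured step, a number 15 percentage points higher from compound 1 to compound 2 (beyond the scatter), also lies beyond the scatter.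

Compound 4 `CCCCc1cc(C(=O)Nc2nn[nH]n2)nc(-c2cccc(C)c2)c1` differs from compound 3 in one place: propyl in place of hydrogen on a saturated chain carbon bound to an aromatic carbon. Both measured steps that go beyond the scatter concern a substituent on an aromatic carbon of the pendant phenyl ring, not the chain on the core, so neither bears directly on this change. Going by the values given here, there is no measured step that varies the chain at all. With nothing to support a move in either direction, a step within the scatter is expected, namely a number 3 percentage points lower from compound 3 to compound 4 (within the scatter). Compound 4 is therefore estimated to give 58% in this assay, with a range from 38% to 78%.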

Compound 4, a percentage reported as inhibition, in the whole organism at one dose (the size of the read-out at that dose, not a potency): 82%
Compound 4: middle estimate off by 24 percentage points, on the low side; the whole stated range lies below it.
By their numbers in this assay, from the lowest: compound 1; then compounds 3 and 2 (each within the scatter of the next); then compound 4.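

In this assay, going by these compounds alone, the change of methyl to butyl gives a number 21 percentage points higher from compound 3 to compound 4 (beyond the scatter) and so shows that the chain on the shared core is a place where the read-out responds, which the earlier steps could not show, as they all concerned a substituent on the pendant phenyl ring. The added propyl brings only carbon, with no ring, no hydrogen-bond donor or acceptor and no net charge, so a purely hydrocarbon extension of this chain is enough to raise the number at the single oral dose tested. Nothing measured here explains why the longer chain gives the higher number.

From the compounds shown here alone, this single pair does not tell whether the number climbs steadily with chain length, so ethyl, propyl, a longer chain such as hexyl and a branched chain such as isopropyl all remain open, as does a chain ending in an amine or a carboxylic acid. It also leaves open whether butyl on the core combines with methoxy on the phenyl ring, the substituent carried by compound 2, to give a further gain.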